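A fluoro for a methyl on compound 1

A few compounds are considered here, and "the series" means these few. Any claim that something is new, unique, unknown or untested is made for them only; others in the source may bear on it.

Compound 1 `Cc1ccc(NC(=O)C(=O)NC(c2nc(C)c(CCO)s2)C2CCCCN2)c(F)c1` gives > 78800 nM
Compound 2 `Cc1ccc(NC(=O)C(=O)NC(c2nc(C)c(CO)s2)C2CCCCN2)c(F)c1` gives > 109000 nM

In an ADME assay on MT2 cells (Homo sapiens) for cytotoxicity, read by XTT assay, with a stated time of 4 days (on this read-out higher numbers stand for lower toxicity in this test and lower numbers for higher toxicity in this test), compound 1 gives only a limit, > 78800 nM, not a number. Among the measured compounds shown here, the one other value, for compound 2, is also a limit. Compound 3 `Cc1nc(C(NC(=O)C(=O)Nc2ccc(F)cc2F)C2CCCCN2)sc1CCO` differs from compound 1 by a single change: fluoro in place of methyl on an aromatic carbon. For the measured compounds named here, the only measured step, a step that the two limits leave unreadable from compound 1 to compound 2, concerns a different change and offers no size to carry over. No step beyond the usual scatter is therefore expected in this assay, and the estimated step is a step that the limit leaves unreadable from compound 1 to compound 3. The estimate for compound 3 is 90000 nM, with an expected range of 40000 nM to 200000 nM.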

Compound 3, half-maximal cytotoxic concentration: > 105000 nM
Compound 3: a limit, no number; the forecaster's own chance of this, stated with the estimate: 85%; middle value at least 1.1-fold (0.06 log units) from the limit.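

Among the compounds shown here, compound 1 and compound 3 both give only limits in this assay, so no step between them can be read. On these data alone, whether fluoro in place of methyl shifts the half-maximal cytotoxic concentration at all remains open.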